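A Chlorine Added to the Benzyl Group

A few compounds are considered here, and "the series" means these few. Any claim that something is new, unique, unknown or untested is made for them only; others in the source may bear on it.

Compound 1 `COc1ccc([C@@H]2CC(=O)c3c(O)cc(OCc4cn(Cc5ccccc5)nn4)cc3O2)cc1O`, 11000 nM
Compound 2 `COc1ccc([C@@H]2C/C(=N\O)c3c(O)cc(OCc4cn(Cc5ccccc5F)nn4)cc3O2)cc1O`, 5710 nM

Of the compounds shown here, two have been measured in a functional assay on RAW264.7 cells (Mus musculus) for inhibition, read by Griess assay, with stated times of 2 h and 24 h; a higher number here means a weaker inhibitor, a lower number a stronger inhibitor. Compound 1 gives 11000 nM, the higher of the two numbers; compound 2 gives 5710 nM, which lies within the scatter of compound 1, so no order can be read between them. Compound 3 `COc1ccc([C@@H]2CC(=O)c3c(O)cc(OCc4cn(Cc5ccccc5Cl)nn4)cc3O2)cc1O` differs from compound 1 in one place: chloro in place of hydrogen on an aromatic carbon. For the measured compounds named here, no single-change step among the measured compounds guides the size of this change, so compound 1 alone anchors the expectation. For compound 3 the expected step is a 1.3-fold lower number from compound 1 to compound 3 (0.11 log units; within the scatter), within the scatter. Compound 3 is thus estimated at 8500 nM, with a range from 3000 nM to 25000 nM.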

Compound 3, half-maximal inhibitory concentration: 6140 nM
The estimate for compound 3 lay 1.4-fold (0.14 log units) above the measured number; the range from low to high includes it.
By their numbers in this assay, from the lowest: compounds 2, 3 and 1 (each within the scatter of the next).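

In this assay, for the compounds shown here, chloro in place of hydrogen, which turns benzyl into 2-chlorobenzyl, gives the first single-change step at this position, a 1.8-fold lower number from compound 1 to compound 3 (0.25 log units; within the scatter), on the core of compound 1. At this place, ortho to a large group, the chlorine is therefore tolerated, and no gain or loss can be read from it. Nothing available explains the size of this step.

As far as these compounds go, whether a methoxy group or an amine at this place would move the number beyond the scatter remains open.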